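Moving a halogen around the aryl ring of compound 1

The compounds below may be only part of what the source reports. "The series", "measured", "known", "first", "only" and "open" are said of these compounds alone.

Compound 1 `COC(=O)C1=C(C)N=C(C)/C(=C(\O)OC)C1c1ccccc1Cl` gives the lowest number of the three measured compounds in a functional assay (muscle tissue) with Cavia porcellus as the target; on this read-out higher numbers stand for an effect only at larger amounts of compound and lower numbers for an effect already at smaller amounts: compound 1 shows 2.19 nM, while compound 2 `COC(=O)C1=C(C)N=C(C)/C(=C(\O)OC)C1c1ccccc1C#N` shows 15.9 nM and compound 3 `COC(=O)C1=C(C)N=C(C)/C(=C(\O)OC)C1c1cccc(N)c1` shows 2000 nM. Compound 4 `COC(=O)C1=C(C)N=C(C)/C(=C(\O)OC)C1c1cccc(I)c1` differs from compound 1 in one place: 3-iodophenyl in place of 2-chlorophenyl on a saturated ring carbon. Among the measured compounds shown here, two measured steps bear on this. The step of a 910-fold higher number from compound 1 to compound 3 (2.96 log units; beyond the scatter) also replaced the 2-chlorophenyl by a group on the 3-position, and the step of a 7.3-fold higher number from compound 1 to compound 2 (0.86 log units; beyond the scatter) changed only the halogen. Because a 910-fold higher number from compound 1 to compound 3 (2.96 log units; beyond the scatter) was so large, a clearly higher number is expected for compound 4, though a halogen rather than an amino group should keep the rise smaller. The estimate for compound 4 is 40 nM (range 8 nM to 200 nM), an expected step of an 18-fold higher number from compound 1 to compound 4 (1.26 log units; beyond the scatter).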

Compound 4, half-maximal effective concentration: 41.7 nM
Estimate against measurement, compound 4: 1.0-fold (0.02 log units) below; the range from low to high includes it.
By their numbers in this assay, from the lowest: compound 1; then compound 2; then compound 4; then compound 3.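

In this assay the two 3-substituted phenyl groups are far apart, with a 48-fold lower number from compound 3 to compound 4 (1.68 log units; beyond the scatter), so the size of the loss seen with 3-aminophenyl depends on the group carried and not only on replacing 2-chlorophenyl. Even so, 3-iodophenyl does not match 2-chlorophenyl, leaving a 19-fold higher number from compound 1 to compound 4 (1.28 log units; beyond the scatter), and it also trails 2-cyanophenyl modestly, with a 2.6-fold higher number from compound 2 to compound 4 (0.42 log units; beyond the scatter). Nothing measured here accounts for these steps. On these data alone, what stays open is how much of the rise belongs to the halogen and how much to its place on the aryl ring, a question that 3-chlorophenyl and 2-iodophenyl groups would separate. As far as these compounds go, how an unsubstituted phenyl group compares also stays open.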